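Amide variation on a shared core: antiproliferative notes

The source may report more compounds than this note shows. Statements on the series, on what has been measured and on what is new or still open speak of the compounds shown alone.

Measured compounds:
compound 1 `O=C(Nc1ccc(Cl)c(-c2nnc3c(Cl)cccn23)c1)c1ccccc1Cl` — > 100000 nM
compound 2 `Cc1cc(Cl)ccc1C(=O)Nc1ccc(Cl)c(-c2nnc3c(Cl)cccn23)c1` — > 100000 nM
compound 3 `CS(=O)(=O)c1cccc(C(=O)Nc2ccc(Cl)c(-c3nnc4c(Cl)cccn34)c2)c1` — > 100000 nM

In a functional assay on AN3-CA cells (Homo sapiens) for antiproliferative activity, read by MTT assay, with a stated time of 72 h (a lower number here means a stronger inhibitor, a higher number a weaker inhibitor), compound 1 gives > 100000 nM, which is a limit of the assay and not a number. Compound 2 gives > 100000 nM, again only a limit. Compound 3 gives > 100000 nM, likewise a limit. Among the compounds with values here, compound 3 therefore stands where every measured compound of the series stands, at the limit of > 100000 nM in this assay, at which 3 of the 3 values shown sit, and no compound can be ordered against another. The steps a step that the two limits leave unreadable from compound 1 to compound 3 and a step that the two limits leave unreadable from compound 2 to compound 3 are the ones that bear on the carbonyl-carbon substituent, and both are unreadable in size because the limit of > 100000 nM in this assay, at which 3 of the 3 values shown sit, caps each end. The same holds for a step that the two limits leave unreadable from compound 1 to compound 2.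

Compound 4 `O=C(Nc1ccc(Cl)c(-c2nnc3c(Cl)cccn23)c1)c1cccnc1` differs from compound 3 as follows: pyridin-3-yl in place of 3-(methylsulfonyl)phenyl on a carbonyl carbon. Within the data shown here, since no measured step on the carbonyl carbon has a readable size, no direction can be taken from them, and the expectation is that compound 4 also sits at the limit. Compound 4 is thus estimated at 100000 nM, with a range from 30000 nM to 300000 nM. The expected step is a number no higher from compound 3 to compound 4 (the limit leaves the size open).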

Compound 4, half-maximal inhibitory concentration: > 100000 nM
Compound 4: a limit, no number; the forecaster's own chance of this, stated with the estimate: 80%; the middle value lies on the limit itself.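

Within the data shown here, compound 4 joins compound 1, compound 2 and compound 3 at a limit in this assay and no step to compound 4 can be read: the limit of > 100000 nM in this assay, at which 4 of the 4 values shown sit.

The compounds shown leave open whether any substituent on the carbonyl carbon of the shared core gives a readable value, and how such substituents would rank.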